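A few compounds are considered here, and "the series" means these few. Any claim that something is new, unique, unknown or untested is made for them only; others in the source may bear on it.

Measured so far in a functional assay on RAW264.7 cells (Mus musculus), with a stated time of 3 days; on this read-out higher numbers stand for weaker inhibition and lower numbers for stronger inhibition:
compound 1, `COc1cnc(-c2ccccn2)nc1C1CCCC1`, gives 1800 nM
compound 2, `COc1cnc(-c2ccccn2)nc1NCCCC(=O)O`, gives > 10000 nM, a limit of the assay and not a number
compound 3, `COc1cnc(-c2ccccn2)nc1NCc1ccccc1`, gives 420 nM

Compound 3 stands at the lowest of the two numbers shown in this assay; compound 1 at 1800 nM sits higher, beyond the scatter. The third value shown, that of compound 2, is a limit of the assay. The measured steps: an at least 5.5-fold higher number from compound 1 to compound 2 (0.74 log units; beyond the scatter), and an at least 23-fold lower number from compound 2 to compound 3 (1.37 log units; beyond the scatter). The first of these ends at a limit, (the limit of > 10000 nM in this assay, at which 1 of the 3 values shown sits), so its true size is not known.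

Compound 4 is `COc1cnc(-c2ccccn2)nc1NCCCCO`. It differs from compound 3 as follows: 3-hydroxypropyl in place of phenyl on a saturated chain carbon bound to a nitrogen on an aromatic ring. This is the reverse direction of the second measured step, in which phenyl entered in place of 2-carboxyethyl, though the chain entering here is 3-hydroxypropyl rather than the 2-carboxyethyl of compound 2. A higher number than that of compound 3 is therefore expected, and the step of a 9.5-fold higher number from compound 3 to compound 4 (0.98 log units; beyond the scatter) is the estimate here, with real possibility that only a limit is reported. In this assay compound 4 is expected to give 4000 nM, within a range from 1200 nM to 15000 nM.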

Compound 4, half-maximal inhibitory concentration: 3000 nM
Beside the measured number, compound 4's estimate is 1.3-fold (0.12 log units) above it, within the range that was stated.
By their numbers in this assay, from the lowest: compound 3; then compounds 1 and 4 (each within the scatter of the next). At a limit, above all of these: compound 2.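

In this assay the change from benzyl to 4-hydroxybutyl gives a 7.1-fold higher number from compound 3 to compound 4 (0.85 log units; beyond the scatter), so at this place the ring-bearing benzyl of compound 3 reads better than this ring-free chain. Hydroxymethyl in place of carboxy on a saturated chain carbon, three bonds along the chain from a nitrogen on an aromatic ring, gives an at least 3.3-fold lower number from compound 2 to compound 4 (0.52 log units; beyond the scatter), a step that starts from the value of compound 2, which is a limit of the assay and not a number, so its true size is unknown: the limit of > 10000 nM in this assay, at which 1 of the 4 values shown sits. (4-Hydroxybutyl)amino in place of cyclopentyl on an aromatic carbon gives a 1.7-fold higher number from compound 1 to compound 4 (0.22 log units; within the scatter), so these two groups cannot be told apart in this assay on the shared core.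

Still open, as far as these compounds go, is whether the missing ring or the hydroxyl on the chain accounts for the gap to compound 3, and a plain butyl chain at this place would separate the two. From the compounds shown here alone, how an amine on the same chain, or a longer chain carrying the hydroxyl, would read also remains open.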